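The source may hold more compounds than are shown below. What is called first, only, known or untested is meant among the compounds shown, and "the series" means these compounds.

Measured compounds, cytotoxicity on MT4 cells:

- compound 1 `CCCCN(CCCC)CN1C(=O)/C(=N\c2ncc(Cc3cc(OC)c(OC)c(OC)c3)c(N)n2)c2cc(Cl)ccc21`: an ADME assay on MT4 cells (Homo sapiens) for cytotoxicity, read by MTT assay, with a stated time of 5 days (a higher number here means that more compound is tolerated, a lower number that less compound is tolerated), 62.6 ug/mL
- compound 2 `COc1cc(Cc2cnc(/N=C3\C(=O)N(CN4CCN(C)CC4)c4ccc(Cl)cc43)nc2N)cc(OC)c1OC`: 80.7 ug/mL
- compound 3 `COc1cc(Cc2cnc(/N=C3\C(=O)N(CN4CCN(c5ccc(F)cc5)CC4)c4ccc(Cl)cc43)nc2N)cc(OC)c1OC`: 65.6 ug/mL

Compound 3 stands second highest of the three numbers, but its step to compound 1 and its step to compound 2 both lie within the usual scatter, so the three values cannot be separated in this assay.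

Compound 4 `COc1cc(Cc2cnc(/N=C3\C(=O)N(CN4CCN(c5ccccn5)CC4)c4ccc(Cl)cc43)nc2N)cc(OC)c1OC` is not yet measured. The change from compound 3 is pyridin-2-yl in place of 4-fluorophenyl on an amine nitrogen in a ring. Among the measured compounds shown here, two measured steps bear on it. The step at the same amine nitrogen in the ring, a 1.2-fold lower number from compound 2 to compound 3 (0.09 log units; within the scatter), brought a large aromatic group in for a methyl and changed nothing beyond the scatter. The earlier step at the saturated chain carbon bound to the amide-type nitrogen, a 1.3-fold higher number from compound 1 to compound 2 (0.11 log units; within the scatter), rebuilt the whole amine end and likewise stayed within the scatter. Neither step gives a direction, and the exchange of one six-membered aromatic ring for another at that amine nitrogen is smaller than either of them. No step beyond the scatter is therefore expected in this assay for compound 4, in either direction.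

The estimate for compound 4 is 65 ug/mL, within 40 ug/mL to 105 ug/mL, that is an expected step of a 1.0-fold lower number from compound 3 to compound 4 (0.00 log units; within the scatter), given that compound 3 gave 65.6 ug/mL.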

Compound 4, half-maximal cytotoxic concentration: 39.2 ug/mL
Compound 4: the middle estimate sits 1.7-fold (0.22 log units) above what was measured, outside the stated range (below it).
By their numbers in this assay, from the lowest: compounds 4, 1, 3 and 2 (each within the scatter of the next, the first and the last beyond it).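

In this assay, pyridin-2-yl in place of 4-fluorophenyl on the amine nitrogen in the ring gives a step that stays within the usual scatter (a 1.7-fold lower number from compound 3 to compound 4 (0.22 log units; within the scatter)), so the exchange of one aromatic ring for the other cannot be read as a change on its own. Among the compounds shown here, the comparison with methyl at the same nitrogen is the first to pass beyond the scatter, though only modestly (a 2.1-fold lower number from compound 2 to compound 4 (0.31 log units; beyond the scatter)), which shows that the group on this nitrogen can move the number in this assay, while the comparison with the dibutylamino end remains within the scatter (a 1.6-fold lower number from compound 1 to compound 4 (0.20 log units; within the scatter)). No measurement at hand accounts for this result.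

Still open, from the compounds shown here alone, is whether the number of compound 4 goes with the ring nitrogen of pyridin-2-yl or with the loss of the fluorine, a question that unsubstituted phenyl or pyridin-4-yl on the same amine nitrogen would help to separate. Also open, going by these compounds, is whether a hydrogen or an acetyl group at this nitrogen would stay with methyl or with pyridin-2-yl in this assay.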